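The source may hold more compounds than are shown below. What is called first, only, known or untested is meant among the compounds shown, and "the series" means these compounds.

Measured so far in an ADME assay on TZM-b1 cells (Homo sapiens) for cytotoxicity, read by XTT assay, with a stated time of 3 days; a higher number here means that more compound is tolerated, a lower number that less compound is tolerated:
compound 1, `Cc1nc(C(NC(=O)C(=O)Nc2ccc(Cl)cc2)C2CCCCN2)sc1CO`: > 22000 nM.
compound 2, `Cc1nc(C(NC(=O)C(=O)Nc2ccc(Cl)cc2)C2CCCCN2)sc1CCO`: 32800 nM.
compound 3, `Cc1nc(C(NC(=O)C(=O)Nc2ccc(Cl)cc2)C2CCNCC2)sc1CO`: 81000 nM.

For compound 1 the entry > 22000 nM is a limit of the assay, not a number. Because of the limit of > 22000 nM in this assay, at which 1 of the 3 values shown sits, the steps a step that the limit leaves unreadable from compound 1 to compound 2 and a step that the limit leaves unreadable from compound 1 to compound 3 cannot be sized, so compound 1 stands only as a limit among the three. Compound 2 and compound 3 each give a readable number in this assay.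

Compound 4, `Cc1nc(C(NC(=O)C(=O)Nc2ccc(F)cc2)C2CCCCN2)sc1CO`, differs from compound 1 in one place: fluoro in place of chloro on an aromatic carbon. Within the data shown here, no measured step touches the six-membered aromatic ring of carbon only, and the two measured steps from compound 1 are unreadable in any case. The expected step that the limit leaves unreadable from compound 1 to compound 4 is therefore nothing beyond the scatter. Compound 4 is expected to give about 30000 nM in this assay, within 15000 nM to 80000 nM.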

Compound 4, half-maximal cytotoxic concentration: > 90000 nM
Compound 4: no number, only a limit; the forecaster's own chance of this, stated with the estimate: 50%; at least 3.0-fold (0.47 log units) between middle value and limit.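

Compound 4 gives > 90000 nM, a limit and not a number. Among these compounds, compound 1 gives > 22000 nM, also a limit, so no step between compound 1 and compound 4 can be read. The compounds shown leave open how 4-fluorophenyl and 4-chlorophenyl compare in this assay.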